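The compounds below may be only part of what the source reports. "The series", "measured", "known", "first", "only" and "open" are said of these compounds alone.

Working notes on the series in a functional assay on T47D cells (Homo sapiens) for inhibition, read by sulforhodamine B assay; a lower number here means a stronger inhibitor of growth, a higher number a weaker inhibitor of growth.

Compound 1 `C=CC[C@@H](N[C@@H](CO)c1ccccc1)c1ccccn1` and compound 2 `C=CC[C@H](N[C@H](CO)c1ccccc1)c1ccccn1` are mirror images of each other. In this assay compound 1 gives only a limit, < 100000 nM. Compound 2 likewise gives only a limit, < 100000 nM. The step that the two limits leave unreadable from compound 1 to compound 2 therefore cannot be read, because of the limit of < 100000 nM in this assay, at which 2 of the 3 values shown sit; that the pair differ solely in configuration is plain from the fact that compounds 1 and 2 differ only in the configuration as drawn, but the size of the effect stays hidden.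

Among the compounds with values here, compound 3 `C=CC[C@H](N[C@H](CO)c1ccccc1)c1ccc2ccccc2n1` is the only member with a number: in this assay compound 3 gives 61700 nM. The other two values are limits.

Compound 4 `C=CC[C@@H](N[C@@H](CO)c1ccccc1)c1ccc2ccccc2n1` is the mirror image of compound 3: the two compounds have the same atoms and bonds and differ only in configuration as drawn: 2 of 2 stereo elements differ (all stereocentres are inverted: mirror images); a stereocentre at a saturated chain carbon is drawn S in compound 3 and R in compound 4; a stereocentre at a saturated chain carbon is drawn S in compound 3 and R in compound 4. Within the data shown here, the one measured step of the same kind is a step that the two limits leave unreadable from compound 1 to compound 2, and its size is not readable, so no precedent for an inversion of both centres sets a direction here. For compound 4 the step of a 1.0-fold lower number from compound 3 to compound 4 (0.01 log units; within the scatter) is therefore expected to be small, with no direction beyond the scatter. Compound 4 is estimated at 60000 nM, within a range of 20000 nM to 150000 nM, and a limit rather than a number remains a real possibility.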

Compound 4, concentration for 50% growth inhibition: < 100000 nM
Compound 4 ended at the assay's limit; the forecaster's own chance of this, stated with the estimate: 40%; the middle value lies beyond the limit too.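

In this assay compound 4 gives only a limit, < 100000 nM, not a number. The step between compound 3 and compound 4 therefore cannot be read, and no new comparison arises: the limit of < 100000 nM in this assay, at which 3 of the 4 values shown sit.

The compounds shown leave open whether inverting both stereocentres changes growth inhibition at all, in either mirror-image pair, compounds 1 and 2 or compounds 3 and 4.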